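Methyl in Place of Nitro: Expected Shift in Potency

This account rests on a few compounds, and the source may have more. Where it says the series, first, only, none or still open, it means among the compounds named here.

Within the data shown here, compound 2, `COc1cccc(Cn2cc(-c3ccc([N+](=O)[O-])cc3)nn2)c1`, is the only compound that gives a number in a functional assay on B16 cells (Mus musculus) for cytotoxicity, read by MTT assay, with a stated time of 48 h; a lower number here means a stronger inhibitor, a higher number a weaker inhibitor: compound 2 gives 19100 nM. Compound 1, `CCOC(=O)Cn1cc(-c2ccc(OC)c(OC)c2OC)nn1`, reaches only a limit in this assay, where compound 1 gives > 100000 nM, which is the limit of > 100000 nM in this assay, at which 1 of the 2 values shown sits. Compound 3, `COc1cccc(Cn2cc(-c3ccc(C)cc3)nn2)c1`, differs from compound 2 by one change: methyl in place of nitro on an aromatic carbon. Among the measured compounds shown here, no measured step of this kind is available, so the expectation rests on compound 2 alone; a modest loss of potency is expected, the step from compound 2 to compound 3 being estimated as a 2.4-fold higher number from compound 2 to compound 3 (0.37 log units; beyond the scatter). Compound 3 is thus expected to give about 45000 nM in this assay, within 15000 nM to 130000 nM.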

Compound 3, half-maximal inhibitory concentration: 19500 nM
For compound 3 the middle estimate is 2.3-fold (0.36 log units) above the measured one; low and high end bracket the measured number.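

In this assay, replacing nitro with methyl on an aromatic carbon, para to a large group, gives a 1.0-fold higher number from compound 2 to compound 3 (0.01 log units; within the scatter), so the two groups cannot be told apart at this position. A single compound could not show this: the position accepts the loss of nitro, with its hydrogen-bond acceptors, and the entry of methyl without a step beyond the scatter. Nothing measured here accounts for this result. Going by these compounds, it remains open how an amine, a carboxylic acid or a longer chain would read at this position. On these data alone, whether nitro and methyl also read alike on another core remains open too.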